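From a Methylated Benzylamine to a Bromobenzyl Secondary Amine

A few compounds are considered here, and "the series" means these few. Any claim that something is new, unique, unknown or untested is made for them only; others in the source may bear on it.

In a functional assay on MCF7 cells (Homo sapiens) for inhibition, read by MTT assay, with a stated time of 72 h (a higher number here means a weaker inhibitor of growth, a lower number a stronger inhibitor of growth), compound 2 `CN(CCCNS(=O)(=O)c1cc(C(F)(F)F)cc(C(F)(F)F)c1)Cc1ccccc1` gives 16000 nM, the higher of the two numbers recorded so far. In this assay compound 1 `CC(C)(C)c1ccc(CNCCCNS(=O)(=O)c2cc(C(F)(F)F)cc(C(F)(F)F)c2)cc1` gives 2100 nM, a gap beyond the scatter. Compound 3 `O=S(=O)(NCCCNCc1ccc(Br)cc1)c1cc(C(F)(F)F)cc(C(F)(F)F)c1` differs from compound 2 by (4-bromobenzyl)amino in place of benzyl(methyl)amino on a saturated chain carbon, three bonds along the chain from a sulfonamide nitrogen. Going by the values given here, no measured pair isolates this change, so the expectation rests on the two values alone. Compound 3 is expected to move toward the lower number because compound 1 gives 2100 nM with a group that likewise carries one hydrogen-bond donor. The estimated step is a 4.6-fold lower number from compound 2 to compound 3 (0.66 log units; beyond the scatter). Compound 3 is estimated at 3500 nM, within 1200 nM to 10000 nM.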

Compound 3, concentration for 50% growth inhibition: 1900 nM
Compound 3: the middle estimate sits 1.8-fold (0.27 log units) above what was measured; the range from low to high includes it.
By their numbers in this assay, from the lowest: compounds 3 and 1 (each within the scatter of the next); then compound 2.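

In this assay, (4-bromobenzyl)amino in place of benzyl(methyl)amino on the saturated chain carbon gives an 8.4-fold lower number from compound 2 to compound 3 (0.93 log units; beyond the scatter), so this position responds to the change. Bromo in place of tert-butyl on an aromatic carbon gives a 1.1-fold lower number from compound 1 to compound 3 (0.04 log units; within the scatter), so the two groups are not told apart here. Nothing measured here gives a reason for either step.

On these data alone, whether a plain benzylamino group would read with compound 2 or with compound 3 stays open, so the larger step cannot yet be divided between the methyl and the bromo. As far as these compounds go, how a methoxy group on that aromatic carbon would read is also open.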